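This account rests on a few compounds, and the source may have more. Where it says the series, first, only, none or still open, it means among the compounds named here.

Working notes on the series. Compound 1 `COc1cc(/C=C/c2nc(Nc3ccc(C)cc3)c3sccc3n2)cc(OC)c1OC`, compound 2 `COc1ccc(Nc2nc(/C=C/c3cc(OC)c(OC)c(OC)c3)nc3ccsc23)cc1` and compound 3 `COc1cc(/C=C/c2nc(Nc3ccc(C(F)(F)F)cc3)c3sccc3n2)cc(OC)c1OC` share one core and differ only in the substituent on the aniline ring. In a functional assay on L02 cells (Homo sapiens) for inhibition, read by Griess assay, with stated times of 1 h and 24 h (a higher number here means a weaker inhibitor, a lower number a stronger inhibitor), compound 1 gives a limit of the assay, < 40000 nM. In this assay compound 2 gives 279000 nM and compound 3 gives 436000 nM, the highest of the two numbers; the gap a 1.6-fold higher number from compound 2 to compound 3 (0.19 log units; within the scatter) lies within the scatter. The step of an at least 10-fold higher number from compound 1 to compound 3 (1.03 log units; beyond the scatter) is large, and the step of an at least 6.9-fold higher number from compound 1 to compound 2 (0.84 log units; beyond the scatter) is at least modest.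

Compound 4 `COc1cc(/C=C/c2nc(NCc3ccccc3Cl)c3sccc3n2)cc(OC)c1OC` awaits measurement; it differs from compound 3 by 2-chlorobenzyl in place of 4-(trifluoromethyl)phenyl on a nitrogen on an aromatic ring. Within the data shown here, none of the measured steps changes the link between the ring and the nitrogen as this one does, so they bear only indirectly: the trifluoromethyl whose entry gave an at least 10-fold higher number from compound 1 to compound 3 (1.03 log units; beyond the scatter) leaves. A modest fall is expected, a 2.2-fold lower number from compound 3 to compound 4 (0.34 log units; beyond the scatter). Compound 4 is estimated at 200000 nM, within 50000 nM to 600000 nM.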

Compound 4, half-maximal inhibitory concentration: > 1000000 nM
Compound 4 was reported as a limit; the forecaster's own chance of this, stated with the estimate: 20%; at least 5.0-fold (0.69 log units) between middle value and limit.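

In this assay compound 4 is the weakest inhibitor of the four, and this first change at the link to the nitrogen gives an at least 2.2-fold higher number from compound 3 to compound 4 (0.36 log units; beyond the scatter), an at least 3.5-fold higher number from compound 2 to compound 4 (0.55 log units; beyond the scatter) and an at least 25-fold higher number from compound 1 to compound 4 (1.39 log units; beyond the scatter). Compound 4 gives a limit and not a number: the limit of > 1000000 nM in this assay, at which 1 of the 4 values shown sits. Compound 1 also gives a limit and not a number: the limit of < 40000 nM in this assay, at which 1 of the 4 values shown sits.

The link and the chlorine change together in compound 4, so their shares cannot be separated. On these data alone, how a plain benzyl group, a phenethyl chain or a carboxylic acid in place of the chlorine would read stays open.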